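Replacing a Methylpiperazinyl Amide with a Pyrrolidinyl Amide

The source may report more compounds than this note shows. Statements on the series, on what has been measured and on what is new or still open speak of the compounds shown alone.

Of the compounds shown here, three sharing one core have been measured in a functional assay on A549 cells (Homo sapiens) for inhibition, read by sulforhodamine B assay, with a stated time of 72 h; a higher number here means a weaker inhibitor, a lower number a stronger inhibitor. Compound 1 `Nc1sc(-c2ccc(Cl)cc2)c(-c2ccc(Cl)cc2)c1C(=O)N1CCCCC1=O` gives 1820 nM. Compound 2 `CC1CN(C(=O)c2c(N)sc(-c3ccc(Cl)cc3)c2-c2ccc(Cl)cc2)CCN1` gives 4930 nM in this assay. Compound 3 `CC(C)(C)NC(=O)c1c(N)sc(-c2ccc(Cl)cc2)c1-c1ccc(Cl)cc1` gives 8850 nM in this assay. Among these three numbers compound 2 stands second highest: its nearest neighbour is compound 3 a 1.8-fold higher number from compound 2 to compound 3 (0.25 log units; within the scatter), and its furthest is compound 1, since a 2.7-fold higher number from compound 1 to compound 2 (0.43 log units; beyond the scatter). The remaining comparison is a 4.9-fold higher number from compound 1 to compound 3 (0.69 log units; beyond the scatter).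

Compound 4 `Nc1sc(-c2ccc(Cl)cc2)c(-c2ccc(Cl)cc2)c1C(=O)N1CCCC1` has not yet been measured. It differs from compound 2 in one place: pyrrolidin-1-yl in place of 3-methylpiperazin-1-yl on a carbonyl carbon. Going by the values given here, no measured step introduces pyrrolidin-1-yl, so the most relevant steps are those that change the same group on the carbonyl carbon: a 2.7-fold higher number from compound 1 to compound 2 (0.43 log units; beyond the scatter) and a 1.8-fold higher number from compound 2 to compound 3 (0.25 log units; within the scatter). These steps are modest or within the scatter, which suggests that swapping groups at this position shifts this assay by only a small amount. Compound 4 is therefore expected to land close to compound 2, with the step of a 1.4-fold lower number from compound 2 to compound 4 (0.15 log units; within the scatter) estimated as small. Compound 4 is estimated at 3500 nM in this assay, in a range from 1200 nM to 10000 nM.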

Compound 4, half-maximal inhibitory concentration: 890 nM
Compound 4: middle estimate off by 3.9-fold (0.59 log units), on the high side; the whole stated range lies above it.
By their numbers in this assay, from the lowest: compound 4; then compound 1; then compounds 2 and 3 (each within the scatter of the next).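

In this assay the group on the carbonyl carbon turns out to matter more than the first three compounds suggested: a 5.5-fold lower number from compound 2 to compound 4 (0.74 log units; beyond the scatter), and a 9.9-fold lower number from compound 3 to compound 4 (1.00 log units; beyond the scatter), both larger than any step seen among those three. Compound 4 also passes the previous best, with a 2.0-fold lower number from compound 1 to compound 4 (0.31 log units; beyond the scatter), so pyrrolidin-1-yl gives the strongest inhibitor of the four, and the position is shown to allow a gain as well as a loss. The change from compound 2 swaps a six-membered non-aromatic ring with 2 hetero atoms, 1 hydrogen-bond donor and 1 hydrogen-bond acceptor for a five-membered non-aromatic ring with 1 hetero atom and neither, but no measurement available here accounts for the gain.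

These compounds do not separate ring size from the loss of the second ring nitrogen and the methyl group, since the change alters all of these at once. Piperidin-1-yl, which keeps the six-membered ring without the second nitrogen, and azetidin-1-yl, a smaller ring still, would be the groups to set beside pyrrolidin-1-yl at this position.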